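A few compounds are considered here, and "the series" means these few. Any claim that something is new, unique, unknown or untested is made for them only; others in the source may bear on it.

Measured so far:
compound 1 `O=C(CSc1nnc(-c2ccncc2)o1)N/N=C/c1ccc(Br)cc1` — 169000 nM
compound 2 `O=C(CSc1nnc(-c2ccncc2)o1)N/N=C/c1ccc(O)cc1` — 158000 nM
compound 3 `O=C(CSc1nnc(-c2ccncc2)o1)N/N=C/c1ccccc1O` — 155000 nM

In an ADME assay on NIH3T3 cells (Mus musculus) for cytotoxicity, read by MTT assay, with a stated time of 24 h (a lower number here means a stronger inhibitor, a higher number a weaker inhibitor), compound 1 gives the highest number of the three, yet its gaps to compound 2 and compound 3 lie within the scatter, so the three cannot be told apart. Compound 4 `O=C(CSc1nnc(-c2ccncc2)o1)N/N=C/c1cc(Br)cc(Br)c1O` differs from compound 1 in one place: 3,5-dibromo-2-hydroxyphenyl in place of 4-bromophenyl on a carbon with a double bond to nitrogen. For the measured compounds named here, the steps that bear on this change are a 1.1-fold lower number from compound 1 to compound 2 (0.03 log units; within the scatter) and a 1.1-fold lower number from compound 1 to compound 3 (0.04 log units; within the scatter), both within the scatter, and likewise a 1.0-fold lower number from compound 2 to compound 3 (0.01 log units; within the scatter). Going by the values given here, nothing among the measured compounds shows the added bromines. The expectation is therefore no step beyond the scatter in this assay, with the estimate for compound 4 at 160000 nM (80000 nM to 320000 nM), meaning an expected step of a 1.1-fold lower number from compound 1 to compound 4 (0.02 log units; within the scatter).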

Compound 4, half-maximal inhibitory concentration: 190000 nM
Beside the measured number, compound 4's estimate is 1.2-fold (0.07 log units) below it, within the range that was stated.
By their numbers in this assay, from the lowest: compounds 3, 2, 1 and 4 (each within the scatter of the next).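

In this assay the 3,5-dibromo-2-hydroxyphenyl group on a carbon with a double bond to nitrogen stays within the scatter of all three earlier groups (a 1.1-fold higher number from compound 1 to compound 4 (0.05 log units; within the scatter); a 1.2-fold higher number from compound 3 to compound 4 (0.09 log units; within the scatter); a 1.2-fold higher number from compound 2 to compound 4 (0.08 log units; within the scatter)). The earlier compounds shown here carried one bromine or one hydroxy on this ring, whereas this result shows that two bromines together with a hydroxy also produce no step that can be read. No separate measurement bears on this result. Going by these compounds, whether an amine or a carboxylic acid on this ring, or a longer chain in its place, would give a step beyond the scatter stays open.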